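Swapping the sulfur-linked arm on a shared core

This account rests on a few compounds, and the source may have more. Where it says the series, first, only, none or still open, it means among the compounds named here.

Compound 1 `Cn1nc(-c2nnc(SCCOc3ccccc3F)o2)cc1-c1ccc(C(F)(F)F)cc1`: 23100 nM
Compound 2 `Cn1nc(-c2nnc(SCc3ccc(Cl)c(Cl)c3)o2)cc1-c1ccc(C(F)(F)F)cc1`: 27200 nM
Compound 3 `Cn1nc(-c2nnc(SCc3ccc(C(F)(F)F)cc3)o2)cc1-c1ccc(C(F)(F)F)cc1`: 15500 nM

Of the compounds shown here, three sharing one core have been tested in a functional assay on MCF7 cells (Homo sapiens) for cytotoxicity, read by MTT assay, with a stated time of 24 h; on this read-out lower numbers stand for stronger inhibition and higher numbers for weaker inhibition; they differ only in the group carried on a saturated chain carbon bound to a sulfur. In this assay compound 1 gives 23100 nM, which places it in the middle of the three numbers. Its closest neighbour is compound 2, with a 1.2-fold higher number from compound 1 to compound 2 (0.07 log units; within the scatter); the furthest is compound 3, with a 1.5-fold lower number from compound 1 to compound 3 (0.17 log units; within the scatter). Between the other two, a 1.8-fold lower number from compound 2 to compound 3 (0.24 log units; within the scatter). None of these steps rises above the scatter, so the three arms behave alike on this read-out.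

Compound 4 `Cn1nc(-c2nnc(SCc3cccc([N+](=O)[O-])c3)o2)cc1-c1ccc(C(F)(F)F)cc1` has not yet been measured. It differs from compound 1 in one place: 3-nitrophenyl in place of (2-fluorophenoxy)methyl on a saturated chain carbon bound to a sulfur. The three measured steps all exchange one arm for another at this same carbon, and all are small, so a further exchange of the same kind is expected to stay small as well. The expected step is a 1.1-fold lower number from compound 1 to compound 4 (0.04 log units; within the scatter), within the scatter. Compound 4 is therefore estimated at 21000 nM, with a likely range from 8000 nM to 50000 nM.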

Compound 4, half-maximal inhibitory concentration: > 100000 nM
Compound 4 was reported as a limit; the forecaster's own chance of this, stated with the estimate: 10%; at least 4.7-fold (0.67 log units) between middle value and limit.
By their numbers in this assay, from the lowest: compounds 3, 1 and 2 (each within the scatter of the next). At a limit, above all of these: compound 4.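

In this assay compound 4 is reported only as a limit, not as a number: the limit of > 100000 nM in this assay, at which 1 of the 4 values shown sits.

Even so, this arm separates from the others by more than the scatter, which no exchange among the first three arms did, with an at least 4.3-fold higher number from compound 1 to compound 4 (0.63 log units; beyond the scatter) and an at least 3.6-fold higher number from compound 2 to compound 4 (0.56 log units; beyond the scatter) and also an at least 6.4-fold higher number from compound 3 to compound 4 (0.80 log units; beyond the scatter). The position on the saturated chain carbon bound to a sulfur is therefore not indifferent to what it carries, and compound 4 is the weakest of the four. Compound 2 and compound 3 also carry a substituted phenyl on this carbon, so a phenyl ring there does not by itself bring the loss, and what sits on the ring matters.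

Going by these compounds, how far compound 4 lies past its limit stays open, and one nitro compound cannot show whether the nitro group itself or its place on the ring decides the outcome. A 4-nitrophenyl arm would test the place, while an amine or a carboxylic acid in place of the nitro group would test the group.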